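The compounds below may be only part of what the source reports. "The series", "measured", "known", "first", "only" and "open" are said of these compounds alone.

Compound 3 `COc1ccc(/C=C\c2cc(OC)c(OC)c(OC)c2)cc1OCc1ccc(CNCCO)cc1` is the only one of the three measured compounds that gives a number in a functional assay on MC-38 cells (Mus musculus) for antiproliferative activity, read by CCK-8 assay, with a stated time of 48 h; on this read-out lower numbers stand for stronger inhibition and higher numbers for weaker inhibition: in that assay compound 3 gives 1200 nM. Compound 1 `COc1ccc(/C=C\c2cc(OC)c(OC)c(OC)c2)cc1OCc1ccc(CN2C[C@H](O)C[C@@H]2C(=O)O)cc1` reaches only a limit of the assay, > 10000 nM. Compound 2 `COc1ccc(/C=C\c2cc(OC)c(OC)c(OC)c2)cc1OCc1ccc(CN2CCCCC2C(=O)NCCN)cc1` likewise gives only a limit, > 10000 nM. Compound 4 `COc1ccc(/C=C\c2cc(OC)c(OC)c(OC)c2)cc1OCc1ccc(CN2CCCC[C@@H]2C(=O)O)cc1` carries 2-carboxypiperidin-1-yl in place of (2-hydroxyethyl)amino on a saturated chain carbon bound to an aromatic carbon. The measured steps that bear on it run the other way: an at least 8.3-fold lower number from compound 1 to compound 3 (0.92 log units; beyond the scatter) and an at least 8.3-fold lower number from compound 2 to compound 3 (0.92 log units; beyond the scatter), each trading a ring-bearing amine for the (2-hydroxyethyl)amino group. Returning to a 2-carboxypiperidin-1-yl, a close relative of the 2-carboxy-4-hydroxypyrrolidin-1-yl of compound 1, is therefore expected to raise the number in this assay, plausibly back toward (the limit of > 10000 nM in this assay, at which 2 of the 3 values shown sit). Compound 4 is estimated at 8000 nM (range 2000 nM to 30000 nM), an expected step of a 6.7-fold higher number from compound 3 to compound 4 (0.82 log units; beyond the scatter).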

Compound 4, half-maximal inhibitory concentration: > 10000 nM
Compound 4 ended at the assay's limit (the forecaster's own chance of this, stated with the estimate: 55%); middle value at least 1.2-fold (0.09 log units) away from the limit.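

In this assay, 2-carboxypiperidin-1-yl on the saturated chain carbon bound to an aromatic carbon gives an at least 8.3-fold higher number from compound 3 to compound 4 (0.92 log units; beyond the scatter). This loss therefore requires neither the hydroxyl of compound 1 nor the aminoethyl amide of compound 2. The steps among compound 1, compound 2 and compound 4 cannot be read, since each compound holds only a limit: the limit of > 10000 nM in this assay, at which 3 of the 4 values shown sit.

The compounds shown do not separate the ring from the carboxylic acid. From the compounds shown here alone, whether an open-chain amine carrying a carboxylic acid, or a longer chain ending in a hydroxyl, would keep the number of compound 3 remains open.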